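A Second Chloro on the Core of Compound 1

The source may hold more compounds than are shown below. What is called first, only, known or untested is meant among the compounds shown, and "the series" means these compounds.

Three compounds built from a chloromethyl-benzyl group on a chlorinated fused core have been tested in a functional assay on M14 cells (Homo sapiens) for cytotoxicity, read by sulforhodamine B assay, with a stated time of 48 h; on this read-out higher numbers stand for weaker inhibition of growth and lower numbers for stronger inhibition of growth. Compound 1 `ClCc1ccc(Cn2cnc3c(Cl)ncnc32)cc1` gives 1280 nM, the lowest of the three numbers, though both neighbours stand within the scatter of it: compound 3 `ClCc1cccc(Cn2cnc3nc(Cl)nc(Cl)c32)c1` gives 1380 nM and compound 2 `ClCc1cccc(Cn2cnc3c(Cl)nc(Cl)nc32)c1` gives 1770 nM. Compound 4 `ClCc1ccc(Cn2cnc3c(Cl)nc(Cl)nc32)cc1` has not yet been measured. It differs from compound 1 by chloro in place of hydrogen on an aromatic carbon. Compounds 2 and 3 carry more chlorine on their cores and yet stand within the scatter of compound 1, so no step beyond the scatter is expected in this assay in either direction. The step of a 1.1-fold higher number from compound 1 to compound 4 (0.04 log units; within the scatter) is estimated to be small. Compound 4 is expected to give about 1400 nM in this assay, within a range from 700 nM to 2800 nM.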

Compound 4, concentration for 50% growth inhibition: 10700 nM
For compound 4 the middle estimate is 7.6-fold (0.88 log units) below the measured one, and the stated range ends below it.
By their numbers in this assay, from the lowest: compounds 1, 3 and 2 (each within the scatter of the next); then compound 4.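

In this assay, chloro in place of hydrogen on this aromatic carbon, between two ring nitrogen atoms, is not a neutral change to the core of compound 1: it brings an 8.4-fold higher number from compound 1 to compound 4 (0.92 log units; beyond the scatter). Compound 2 carries the same chlorinated core with the chloromethyl group placed differently on the benzyl ring, and compound 2 gives 1770 nM, so this core alone does not set the higher number of compound 4. Nothing available here explains the step. On these data alone, whether an amine or a methoxy group on this carbon would behave like hydrogen or like chloro remains open.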